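The compounds below may be only part of what the source reports. "The series", "measured", "known", "first", "only" and "open" are said of these compounds alone.

Compound 1 `COc1cc(NC(C)CCCNC(=O)Nc2cccc(Cl)c2)c2ncccc2c1` gives 26000 nM
Compound 2 `COc1cc(NC(C)CCCNC(=O)NNC(=O)Nc2cccc(F)c2)c2ncccc2c1` gives 9500 nM

Both numbers come from a functional assay on SW-620 cells (Homo sapiens) for inhibition, read by MTT assay, with a stated time of 72 h (on this read-out lower numbers stand for stronger inhibition and higher numbers for weaker inhibition), and compound 2 holds the lower of the two. Compound 3 `COc1cc(NC(C)CCCNC(=O)NNC(=O)Nc2ccc(O)cc2)c2ncccc2c1` is still unmeasured and differs from compound 2 on an amide-type nitrogen (4-hydroxyphenyl in place of 3-fluorophenyl on an amide-type nitrogen). For the measured compounds named here, the only measured step (a 2.7-fold lower number from compound 1 to compound 2 (0.44 log units; beyond the scatter)) was modest and did not exchange one phenyl group for another alone, so it offers only a rough guide to size. In this assay, no change beyond the scatter is therefore expected (a 1.2-fold higher number from compound 2 to compound 3 (0.06 log units; within the scatter)). For compound 3, the estimated value is 11000 nM, with an expected range from 3500 nM to 35000 nM in repeated measurements.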

Compound 3, half-maximal inhibitory concentration: > 100000 nM
Compound 3: no number, only a limit; the forecaster's own chance of this, stated with the estimate: 15%; at least 9.0-fold (0.95 log units) between middle value and limit.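

In this assay compound 3 reaches no number, only a limit: the limit of > 100000 nM in this assay, at which 1 of the 3 values shown sits. Putting 4-hydroxyphenyl in place of 3-fluorophenyl on the amide-type nitrogen gives an at least 10-fold higher number from compound 2 to compound 3 (1.02 log units; beyond the scatter), so the substituted phenyl group at this position matters greatly. The longer ((4-hydroxyphenyl)carbamoyl)amino group also gives an at least 3.8-fold higher number from compound 1 to compound 3 (0.58 log units; beyond the scatter), so the longer group does not by itself bring the lower number seen with compound 2.

Still open, going by these compounds, is whether the hydroxy group or its place on the ring matters: a 3-hydroxyphenyl group would separate the two, and a 4-aminophenyl group would show whether another group behaves alike.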